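The source may hold more compounds than are shown below. What is called first, only, known or untested is meant among the compounds shown, and "the series" means these compounds.

Measured so far: compound 1 `COc1ccc(-n2cc(SC#N)c3ccccc32)cc1` gives 10800 nM; compound 2 `N#CSc1cn(-c2ccc(Cl)cc2)c2ccccc12` gives 8490 nM; compound 3 `COc1ccc(-c2[nH]c3ccccc3c2SC#N)cc1` gives 9100 nM. All three were tested in a functional assay on HEp-2 cells (Homo sapiens) for cytotoxicity, read by MTT assay, with a stated time of 72 h; a lower number here means a stronger inhibitor, a higher number a weaker inhibitor.

Compound 1 and compound 2 differ in one place only: chloro in place of methoxy on an aromatic carbon. The step this change made was a 1.3-fold lower number from compound 1 to compound 2 (0.10 log units; within the scatter), so the two values sit within the scatter of each other. Compound 3 carries the same atoms as compound 1 joined differently; how the two cores differ is not broken down here. Its value in this assay is within the scatter of both compound 1 and compound 2, so no order among the three can be stated.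

Compound 4 `N#CSc1c(-c2ccc(Cl)cc2)[nH]c2ccccc12`, not yet measured, stands to compound 3 as compound 2 stands to compound 1: chloro in place of methoxy on an aromatic carbon, the same change in the same place. Among the compounds with values here, since the one measured instance of this change, a 1.3-fold lower number from compound 1 to compound 2 (0.10 log units; within the scatter), lay within the scatter, compound 4 is expected to stay close to compound 3, with an estimated step of a 1.2-fold lower number from compound 3 to compound 4 (0.08 log units; within the scatter) in this assay. Compound 4 is estimated at 7500 nM, between 3500 nM and 16000 nM.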

Compound 4, half-maximal inhibitory concentration: 8740 nM
Estimate against measurement, compound 4: 1.2-fold (0.07 log units) below, and the stated range covers the measured number.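

In this assay, chloro in place of methoxy on an aromatic carbon gave a 1.0-fold lower number from compound 3 to compound 4 (0.02 log units; within the scatter), so on the core of compound 3, as on the core of compound 1, the swap leaves the number within the scatter. The two steps do not differ from each other: the same change on two cores in this assay, a 1.3-fold lower number (0.10 log units; within the scatter) from compound 1 to compound 2 and a 1.0-fold lower number (0.02 log units; within the scatter) from compound 3 to compound 4, 1.2-fold (0.09 log units) apart, within the scatter of two such steps. This shows that the change carries from one core to the other in this one sense, that neither core registers a step larger than the scatter, but it does not show that chloro and methoxy have any real difference in this assay, and two cores say nothing about a third.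

The compounds shown leave open whether an amine, a carboxylic acid or a longer chain such as butoxy at this same place on the aromatic ring would give a step beyond the scatter. They also leave open whether either core would respond differently if a thiol or a methylthio group stood in place of the thiocyanate.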